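From compound 1 to compound 4 on the sulfur chain

The compounds below may be only part of what the source reports. "The series", "measured", "known", "first", "only" and "open" are said of these compounds alone.

Compound 1 `Cc1cc(Nc2cc(-c3ccccc3)[nH]n2)n2nc(SCCc3ccccc3)nc2n1`: 37400 nM
Compound 2 `CCCCCc1c(C)nc2nc(SCc3ccc(Cl)cc3)nn2c1Nc1cc(-c2ccccc2)[nH]n1`: > 50000 nM, a limit of the assay
Compound 3 `Cc1cc(Nc2cc(-c3ccccc3)[nH]n2)n2nc(SCC(=O)c3ccccc3)nc2n1`: 33300 nM

Within the data shown here, in an ADME assay on GES1 cells (Homo sapiens) for inhibition, read by MTT assay, with a stated time of 72 h (on this read-out higher numbers stand for weaker inhibition and lower numbers for stronger inhibition), compound 1 gives 37400 nM, and its only neighbour with a true number is compound 3. Compound 2 gives no number, only (the limit of > 50000 nM in this assay, at which 1 of the 3 values shown sits). Compound 4 `Cc1cc(Nc2cc(-c3ccccc3)[nH]n2)n2nc(SCc3ccccc3Br)nc2n1` changes the side chain of compound 1: 2-bromophenyl in place of benzyl on a saturated chain carbon bound to a sulfur, with 2-bromophenyl in place of benzyl on a saturated chain carbon bound to a sulfur. Among the measured compounds shown here, one measured step bears on this place, a 1.1-fold lower number from compound 1 to compound 3 (0.05 log units; within the scatter). On that evidence, no shift beyond the scatter is expected in this assay. The estimated step is a 1.1-fold lower number from compound 1 to compound 4 (0.05 log units; within the scatter). For compound 4 the expected value is 33000 nM, with an estimated range of 15000 nM to 50000 nM.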

Compound 4, half-maximal inhibitory concentration: 41100 nM
Compound 4: middle estimate off by 1.2-fold (0.10 log units), on the low side; the measured number falls inside the stated range.
By their numbers in this assay, from the lowest: compounds 3, 1 and 4 (each within the scatter of the next). At a limit, above all of these: compound 2.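

In this assay, 2-bromophenyl in place of benzyl gives a 1.1-fold higher number from compound 1 to compound 4 (0.04 log units; within the scatter), and 2-bromophenyl in place of benzoyl gives a 1.2-fold higher number from compound 3 to compound 4 (0.09 log units; within the scatter). The place on the saturated chain carbon bound to a sulfur has now taken a bromine-bearing group as well as a carbonyl-bearing one, and compounds 1, 3 and 4 still cannot be told apart. No measurement shown gives a reason for these steps. From the compounds shown here alone, whether an amine, a carboxylic acid or a longer chain in this place would give a number beyond the scatter remains open.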